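Swapping methyl for nitro on the anilide ring

This account rests on a few compounds, and the source may have more. Where it says the series, first, only, none or still open, it means among the compounds named here.

Measured so far in a functional assay on the whole organism (strain Wistar) for inhibition, with Rattus norvegicus as the target, read by paw edema, with a stated time of 6 h, at a dose of 100 mg/kg; a lower number here means less inhibition, a higher number more inhibition at the dose given (going by the name of the read-out):
- compound 1 `COc1cc2c(cc1OC)C(CC(=O)Nc1ccccc1)CC2`: 38.9%
- compound 2 `COc1cc2c(cc1OC)C(CC(=O)Nc1ccc(Br)cc1)CC2`: 46.3%
- compound 3 `COc1cc2c(cc1OC)C(CC(=O)Nc1ccc(C)cc1)CC2`: 37%

Compound 3 stands at the low end of these three numbers, yet neither gap sets it apart: the step of a number 1.9 percentage points lower from compound 1 to compound 3 (within the scatter) and the step of a number 9.3 percentage points lower from compound 2 to compound 3 (within the scatter) both stay inside the scatter of repeated runs. All three compounds share one core and differ only in the group on the anilide ring.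

Compound 4 `COc1cc2c(cc1OC)C(CC(=O)Nc1ccc([N+](=O)[O-])cc1)CC2` carries the change (nitro in place of methyl on an aromatic carbon). Within the data shown here, two measured steps bear on it, since both exchange the group at that same place: a number 1.9 percentage points lower from compound 1 to compound 3 (within the scatter) and a number 9.3 percentage points lower from compound 2 to compound 3 (within the scatter), and the related step of a number 7.4 percentage points higher from compound 1 to compound 2 (within the scatter) is also inside the scatter. None of these exchanges moved this assay beyond its noise, so the nitro is expected to do no more, with at most a modest tilt upward of the kind seen for bromo. The step of a number 5 percentage points higher from compound 3 to compound 4 (within the scatter) is therefore expected to stay within the scatter. For compound 4 a value of 42% is estimated, with a range from 30% to 54%.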

Compound 4, a percentage reported as inhibition, in the whole organism at one dose (the size of the read-out at that dose, not a potency): 37%
For compound 4 the middle estimate is 5 percentage points above the measured one; the range from low to high includes it.
By their numbers in this assay, from the lowest: compounds 3, 4, 1 and 2 (each within the scatter of the next).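

In this assay, nitro, with its three heavy atoms and two hydrogen-bond acceptors, reads no differently from methyl, with its single carbon and no acceptors: the step is no change at the digits printed from compound 3 to compound 4 (within the scatter) for this exchange on the aromatic carbon. The comparisons with the other two groups, a number 9.3 percentage points lower from compound 2 to compound 4 (within the scatter) and a number 1.9 percentage points lower from compound 1 to compound 4 (within the scatter), also stay within the scatter, so hydrogen, methyl, bromo and nitro at this place cannot be told apart at this dose, and the size of the group alone has not separated any of them here. No measurement available explains why these groups read alike.

The compounds shown leave open whether an amine, a carboxylic acid or a longer chain at this same place would give a step beyond the scatter. They also leave open whether any group at another place on the anilide ring would do so.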